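Fluoro Removal at the Benzyl Group and Cytotoxicity

A few compounds are considered here, and "the series" means these few. Any claim that something is new, unique, unknown or untested is made for them only; others in the source may bear on it.

Compound 1 `Cc1ccccc1-c1nn(Cc2ccc(F)cc2)cc1CNCCN1CCN(C)CC1` has been examined in an ADME assay on Huh-7 cells (Homo sapiens) for cytotoxicity; a lower number here means that less compound is tolerated, a higher number that more compound is tolerated. Compound 1 gives > 20000 nM, which is a limit of the assay rather than a number. Compound 2 `CCCN1CCC(CNCc2cn(-c3ccc(F)cc3F)nc2-c2ccccc2C)CC1` likewise gives > 20000 nM, also a limit. Compound 3 `COC(=O)c1ccc(-c2nn(-c3ccc(F)cc3F)cc2CNCCN2CCN(C)CC2)cc1` gives > 20000 nM, again a limit. Compound 1 thus sits at the limit of > 20000 nM in this assay, at which 3 of the 3 values shown sit, and nothing in this assay sets any of these three apart from the others. Compound 4 `Cc1ccccc1-c1nn(Cc2ccccc2)cc1CNCCN1CCN(C)CC1` is not yet measured; it differs from compound 1 by hydrogen in place of fluoro on an aromatic carbon. Among the compounds with values here, no measured pair shows what this change does in this assay. The step is expected to be none beyond the scatter, a step that the limit leaves unreadable from compound 1 to compound 4. Compound 4 is therefore estimated at 25000 nM, between 10000 nM and 60000 nM, most likely reported once more as a limit.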

Compound 4, half-maximal cytotoxic concentration: > 20000 nM
Compound 4: no number, only a limit; the forecaster's own chance of this, stated with the estimate: 85%; the middle value does not contradict the limit.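

In this assay compound 4 gives > 20000 nM, a limit. Within the data shown here, compound 1 gives > 20000 nM, also a limit, so no step between compound 1 and compound 4 can be read. The compounds shown leave open whether 4-fluorobenzyl to benzyl changes cytotoxicity at all.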